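The compounds below may be only part of what the source reports. "The series", "measured", "known", "first", "only" and "open" are said of these compounds alone.

Measured so far in an in vitro ADME assay on microsomes from liver (Mus musculus) for pharmacokinetics, read by LC-MS (on this read-out lower numbers stand for slow clearance and higher numbers for fast clearance), are these compounds:
compound 1 (`Cc1ccc2nc(C)n(-c3ccc(C(=O)NC4CC4)s3)c2c1`) gives > 72 mL/min/kg as a limit
compound 2 (`COc1cccc2c1nc(C)n2-c1ccc(C(=O)NC2CC2)s1`) gives > 72 mL/min/kg as a limit
compound 3 (`Cc1nc2c(F)cccc2n1-c1ccc(C(=O)NC2CC2)s1`) gives 37 mL/min/kg as a number

Within the data shown here, compound 3 holds the only true number. Compound 1 and compound 2 share the limit of > 72 mL/min/kg in this assay, at which 2 of the 3 values shown sit, and neither gives a number.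

Compound 4 (`Cc1cc(F)c2nc(C)n(-c3ccc(C(=O)NC4CC4)s3)c2c1`) differs from compound 3 by a methyl in place of hydrogen on an aromatic carbon, meta to a fluoro group (methyl in place of hydrogen on an aromatic carbon). Among the measured compounds shown here, the only measured step (an at least 1.9-fold lower number from compound 2 to compound 3 (0.28 log units; that floor lies within the scatter)) is a fluoro in place of methoxy, a different change, so it bears on this one only indirectly. Compound 1 carries a methyl on the core and no fluoro group, and its reading of > 72 mL/min/kg is a limit. On that reading, a modest move towards faster clearance is expected in this assay for this change. The expected step (a 1.5-fold higher number from compound 3 to compound 4 (0.17 log units; within the scatter)) is small. For compound 4 the estimate is 55 mL/min/kg with an expected range of 30 mL/min/kg to 72 mL/min/kg and a real chance of a limit instead of a number.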

Compound 4, clearance: > 72 mL/min/kg
Compound 4: only a limit was reported; the forecaster's own chance of this, stated with the estimate: 35%; middle value at least 1.3-fold (0.11 log units) from the limit.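

In this assay, methyl in place of hydrogen on this aromatic carbon, meta to a fluoro group, gives an at least 1.9-fold higher number from compound 3 to compound 4 (0.28 log units; that floor lies within the scatter), so a fluoro group on the core does not by itself secure a true number once this methyl is present. As far as these compounds go, compound 4 gives only a limit, > 72 mL/min/kg, and so joins the reading that dominates the series: the limit of > 72 mL/min/kg in this assay, at which 3 of the 4 values shown sit. The step from compound 1 to compound 4 cannot be read, as both ends are limits, and the fluoro group's contribution in the methyl-bearing core stays unknown.

From the compounds shown here alone, how far compound 4 lies past its limit remains open, and with it the true size of the methyl step. Also open, going by these compounds, is whether a nitrile or a hydroxymethyl at this position would give a number rather than a limit.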